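Fluorine on the Phenyl Ring of a Fatty Acid Receptor Agonist

The source may report more compounds than this note shows. Statements on the series, on what has been measured and on what is new or still open speak of the compounds shown alone.

Measured so far:
compound 1, `Cc1nc(-c2ccc(C(F)(F)F)cc2)sc1COc1ccc(OCC(=O)O)c(F)c1`, 149 nM
compound 2, `Cc1nc(-c2ccccc2)sc1COc1ccc2c(c1)OCC2CC(=O)O`, 102 nM

In an assay on CHO cells for agonist activity at Free fatty acid receptor 1 (Homo sapiens), read by FLIPR (a higher number here means that more compound is needed for the effect, a lower number that less compound is needed), compound 2 has the lowest of the two numbers, but compound 1 lies within the usual scatter of it, so the two cannot be ranked. Compound 3, `Cc1nc(-c2ccc(F)cc2)sc1COc1ccc2c(c1)OCC2CC(=O)O`, differs from compound 2 by a single change: fluoro in place of hydrogen on an aromatic carbon. Among the compounds with values here, no pair of measured compounds shows this exact step, so no measured guide exists for its size. For compound 3 the expected step of a 1.2-fold lower number from compound 2 to compound 3 (0.08 log units; within the scatter) is small, likely no more than the scatter, and compound 3 is therefore estimated at 85 nM, with a range from 35 nM to 210 nM.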

Compound 3, half-maximal effective concentration: 79 nM
Estimate against measurement, compound 3: 1.1-fold (0.03 log units) above; the measured number falls inside the stated range.
By their numbers in this assay, from the lowest: compounds 3, 2 and 1 (each within the scatter of the next).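

In this assay the change from phenyl to 4-fluorophenyl gives a 1.3-fold lower number from compound 2 to compound 3 (0.11 log units; within the scatter) and so leaves the two compounds unranked. Within the data shown here, this is the first single-place step, and it shows that fluoro can take the place of hydrogen on this aromatic carbon, para to a large group, without a change beyond the scatter. Nothing measured here offers an explanation for this result.

Still open, from the compounds shown here alone, is how chloro, methoxy or an amine would read at this same carbon. Also open, going by these compounds, is whether fluoro on another carbon of this ring would give a similar result.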